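A few compounds are considered here, and "the series" means these few. Any claim that something is new, unique, unknown or untested is made for them only; others in the source may bear on it.

Measured compounds:
- compound 1 `Cc1ccccc1-n1nc(C)c2c1NC(=O)[C@H](C)S[C@@H]2c1ccc(/C=C/c2ccccc2)cc1`: in an assay on isolated protein for agonist activity at Bile acid receptor (Homo sapiens), read by AlphaScreen, with a stated time of 30 min (on this read-out lower numbers stand for an effect already at smaller amounts and higher numbers for an effect only at larger amounts of compound), compound 1 is reported as "not active" (no number reported)
- compound 2 `CCCc1ccccc1-n1nc(C)c2c1NC(=O)[C@H](C)S[C@@H]2c1ccc(Oc2ccccc2)cc1`: in this assay compound 2 gives 1100 nM

Compound 1 stands without a number in this assay: it carries only the remark that no activity was seen. Among the measured compounds shown here, compound 2 shares the core but differs in two places from compound 1, so no single step is counted between them; the two entries only show that a measurable half-maximal effective concentration does appear once the phenoxy-type group is present.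

Compound 3 `Cc1ccccc1-n1nc(C)c2c1NC(=O)[C@H](C)S[C@@H]2c1ccc(Oc2cccc(C(=O)O)c2)cc1` is to be measured. It differs from compound 1 by 3-carboxyphenoxy in place of 2-phenylethenyl on an aromatic carbon. For the measured compounds named here, no step between measured compounds exists for this change, so its size can only be expected. Given that compound 1 is reported as "not active" (no number reported) and that compound 2, carrying a related phenoxy group, gives 1100 nM, the change is expected to move compound 3 from no activity to a measurable value, a step well beyond the scatter, towards the low end. For compound 3 the half-maximal effective concentration in this assay is estimated at 500 nM, with a range from 100 nM to 3000 nM.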

Compound 3, half-maximal effective concentration: "not active" (no number reported)
For compound 3 the study gives words and no number; there is nothing to compare the estimate with.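

In this assay compound 1 is reported as "not active" (no number reported) and compound 3 as "not active" (no number reported), so no step can be read between them. The compounds shown leave open what separates both from compound 2, which differs from each in two places. Nothing shown explains the result for compound 3.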